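The compounds below may be only part of what the source reports. "The series", "measured", "known", "first", "only" and "open" are said of these compounds alone.

Measured so far in a functional assay on K562/A02 cells (Homo sapiens) for antiproliferative activity, read by MTT assay; on this read-out lower numbers stand for stronger inhibition and higher numbers for weaker inhibition:
- compound 1 `O=C(CCCCCNC(=S)NN=C(c1ccccc1)c1ccccc1)NO`: 3640 nM
- compound 2 `O=C(CCCCCNC(=S)N/N=C(\c1ccccc1)c1ccccc1F)NO`: 6010 nM

Within the data shown here, on these two numbers compound 2 stands highest, though the only measured step, a 1.7-fold higher number from compound 1 to compound 2 (0.22 log units; within the scatter), is within the scatter, so neither compound can be called stronger. That step added fluoro in place of hydrogen on an aromatic carbon.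

Compound 3 `COc1ccccc1/C(=N/NC(=S)NCCCCCC(=O)NO)c1ccccc1` differs from compound 2 in one place: methoxy in place of fluoro on an aromatic carbon. Among the measured compounds shown here, no measured step trades fluoro for methoxy, so nothing here shows what such a swap does. For the measured compounds named here, the single known change at this ring stayed within the scatter, and on that basis the expected step is a 1.2-fold lower number from compound 2 to compound 3 (0.08 log units; within the scatter). For compound 3 the estimate is 5000 nM, from 2500 nM to 12000 nM.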

Compound 3, half-maximal inhibitory concentration: 2910 nM
For compound 3 the middle estimate is 1.7-fold (0.24 log units) above the measured one; the measured number falls inside the stated range.
By their numbers in this assay, from the lowest: compounds 3, 1 and 2 (each within the scatter of the next, the first and the last beyond it).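

In this assay, among these compounds, the change from 2-fluorophenyl to 2-methoxyphenyl gives a 2.1-fold lower number from compound 2 to compound 3 (0.31 log units; beyond the scatter) as the only step so far beyond the scatter, and a modest one. Methoxy in place of hydrogen at the same position gives a 1.3-fold lower number from compound 1 to compound 3 (0.10 log units; within the scatter) and so cannot be told apart from hydrogen, which leaves only methoxy and fluoro distinct here. Nothing measured bears on why these two groups differ.

As far as these compounds go, whether ethoxy, hydroxy or an amine at this position would match methoxy remains open. So does whether methoxy would read the same on another carbon of this ring.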